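A few compounds are considered here, and "the series" means these few. Any claim that something is new, unique, unknown or untested is made for them only; others in the source may bear on it.

Measured so far:
compound 1 `CC(=O)SCC(=O)c1ccc(NS(=O)(=O)c2ccc(OCc3ccccn3)cc2)nc1` — "not determined" (no result reported) in a functional assay on U226 cells (Homo sapiens) for cytotoxicity; a lower number here means that less compound is needed, a higher number that more compound is needed for the effect
compound 2 `CC(=O)SCC(=O)c1ccc(NS(=O)(=O)c2ccc3c(c2)COOC3)nc1` — 2000 nM in this assay

Compound 1 stands nowhere on the numbers: in this assay compound 1 has "not determined" (no result reported) and no single value, so it offers no anchor. In this assay compound 2 gives 2000 nM. The change from compound 1 to compound 3 `CC(=O)SCC(=O)c1ccc(NS(=O)(=O)c2ccc(OC3CCCN(C)C3)cc2)nc1` is 1-methylpiperidin-3-yl in place of (pyridin-2-yl)methyl on an oxygen on an aromatic ring. With no number for compound 1, the size of this step in this assay cannot be judged, and no direction beyond the scatter can be claimed; the value of compound 2 is the only point of reference. Compound 3 is therefore expected near 2000 nM, in a range from 400 nM to 10000 nM.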

Compound 3, half-maximal effective concentration: 1200 nM
Estimate against measurement, compound 3: 1.7-fold (0.22 log units) above; measured number inside the range.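

In this assay, among the compounds shown here, compound 3 gives 1200 nM, but compound 1 offers no number to set beside it, so no step between them can be read. The compounds shown leave open how (1-methylpiperidin-3-yl)oxy compares with (pyridin-2-yl)methoxy in this assay. Nothing available bears on this result.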